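Cytotoxicity notes on the shared core series

This account rests on a few compounds, and the source may have more. Where it says the series, first, only, none or still open, it means among the compounds named here.

Compound 1 `CCC(CC)O[C@@H]1C=C(C(=O)O)C[C@H](NCc2ccc(OC)cc2)[C@H]1NC(C)=O` is the reference point. In an ADME assay on cells (Fibroblast, Gallus gallus) for cytotoxicity, read by CCK-8 assay, with a stated time of 48 h (a lower number here means that less compound is tolerated, a higher number that more compound is tolerated), compound 1 gives > 200000 nM, which is a limit of the assay rather than a number. Compound 2 `CCC(CC)Oc1cccc(CN[C@H]2CC(C(=O)O)=C[C@@H](OC(CC)CC)[C@@H]2NC(C)=O)c1` carries the same core with a different substitution; in this assay compound 2 gives > 200000 nM, again only a limit. Among the compounds with values here, both results sit at the limit of > 200000 nM in this assay, at which 2 of the 2 values shown sit, so no step between measured compounds can be sized, and compound 1 stands at the edge of what the assay reports. Compound 3 `CCC(CC)O[C@@H]1C=C(C(=O)O)C[C@H](NCc2ccc(-c3ccc4sccc4c3)cc2)[C@H]1NC(C)=O` is the next entry to be measured. Relative to compound 1 the change is 1-benzothiophen-5-yl in place of methoxy on an aromatic carbon. Within the data shown here, with no measured step to lean on, the expected outcome is an at least 1.6-fold lower number from compound 1 to compound 3 (0.22 log units; that floor lies within the scatter), a modest move toward less tolerated, although a result that again reaches only the limit remains plausible. Compound 3 is therefore estimated at 120000 nM, with a range from 30000 nM to 250000 nM.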

Compound 3, half-maximal cytotoxic concentration: > 200000 nM
Compound 3: only a limit was reported; the forecaster's own chance of this, stated with the estimate: 50%; at least 1.6-fold (0.22 log units) between middle value and limit.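

No step can be read from compound 1 to compound 3, since both results are limits and not numbers: the limit of > 200000 nM in this assay, at which 3 of the 3 values shown sit.

The compounds shown leave open whether 1-benzothiophen-5-yl in place of methoxy changes tolerance at all, and how much compound any of the three tolerated cells would withstand beyond that limit.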